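The source may report more compounds than this note shows. Statements on the series, on what has been measured and on what is new or still open speak of the compounds shown alone.

Compound 1, `O=S(=O)(Nc1ccc(-c2nc3ccccc3o2)cc1)c1ccccc1F`: in an assay on isolated protein for inhibition of malate dehydrogenase, mitochondrial (Sus scrofa), with stated times of 45 min and 30 min (a lower number here means a stronger inhibitor, a higher number a weaker inhibitor), compound 1 gives > 63000 nM, which is a limit of the assay and not a number.
Compound 2, `COc1ccccc1S(=O)(=O)Nc1ccc(-c2nc3ccccc3o2)cc1`: in this assay compound 2 gives > 63000 nM, again a limit.
Compound 3, `O=S(=O)(Nc1ccc(-c2nc3ccccc3o2)cc1)c1ccc(F)cc1`: in this assay compound 3 gives > 63000 nM, also a limit.

All three measured compounds share the same core and differ only in the ring attached to the sulfonyl sulfur. Compound 3 therefore stands nowhere distinct: its value in this assay is a limit, and so are the two others, as stated in the limit of > 63000 nM in this assay, at which 3 of the 3 values shown sit. The steps a step that the two limits leave unreadable from compound 1 to compound 2, a step that the two limits leave unreadable from compound 1 to compound 3 and a step that the two limits leave unreadable from compound 2 to compound 3 are all unreadable for that reason.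

Compound 4, `O=S(=O)(Nc1ccc(-c2nc3ccccc3o2)cc1)c1ccc(Cl)c(Cl)c1`, is the next variant. The change from compound 3 is 3,4-dichlorophenyl in place of 4-fluorophenyl on a sulfonyl sulfur. Every measured step that bears on this position is unreadable, since the three values sit at a limit in this assay, so no direction or size can be taken from them. The only expectation the data support is that compound 4 will most likely also be reported as a limit in this assay, and the estimated step that the limit leaves unreadable from compound 3 to compound 4 is expected to be essentially none. The estimate for compound 4 is 80000 nM, in the range from 15000 nM to 400000 nM.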

Compound 4, half-maximal inhibitory concentration: > 63000 nM
Compound 4 gave a limit, no number; the forecaster's own chance of this, stated with the estimate: 85%; the middle value lies beyond the limit too.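

Compound 4 also gives a limit and not a number, so its steps from compound 1, compound 2 and compound 3 cannot be read: the limit of > 63000 nM in this assay, at which 4 of the 4 values shown sit.

The compounds shown leave open whether any group on the sulfonyl sulfur would give a measurable value in this assay.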